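A trifluoromethyl swap at the limit of a cytotoxicity read-out

The source may hold more compounds than are shown below. What is called first, only, known or untested is meant among the compounds shown, and "the series" means these compounds.

compound 1 `CCc1ccc(NC(=O)Nc2cc(C)nc3ccccc23)cc1` gives > 25000 nM (a limit)
compound 2 `Cc1cc(NC(=O)Nc2ccc(F)cc2)c2ccccc2n1` gives > 25000 nM (a limit)

In an ADME assay on BJ cells (Homo sapiens) for cytotoxicity, with a stated time of 72 h (on this read-out lower numbers stand for an effect already at smaller amounts and higher numbers for an effect only at larger amounts of compound), compound 2 gives > 25000 nM as a limit and not as a number. Its exact place on the scale therefore cannot be read. The evidence so far is the limit of > 25000 nM in this assay, at which 2 of the 2 values shown sit, and nothing more.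

The next compound is compound 3 `Cc1cc(NC(=O)Nc2ccc(C(F)(F)F)cc2)c2ccccc2n1` and the change is trifluoromethyl in place of fluoro on an aromatic carbon in which trifluoromethyl takes the place of fluoro on an aromatic carbon. Among the compounds with values here, only one measured step bears on this, a swap of fluoro in place of ethyl on an aromatic carbon. That step is a step that the two limits leave unreadable from compound 1 to compound 2 and it offers no size to carry over.

With no readable step to draw on, no clear move in either direction is expected. The expected change is a number no higher from compound 2 to compound 3 (the limit leaves the size open) in this assay and another limit is the likeliest report. For compound 3 the estimate is 25000 nM with an expected range from 8000 nM to 40000 nM as the span of likely results.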

Compound 3, half-maximal effective concentration: > 25000 nM
Compound 3 gave a limit, no number; the forecaster's own chance of this, stated with the estimate: 65%; the middle value lies on the limit itself.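

No step can be read among compound 1, compound 2 and compound 3, since each gives only a limit in this assay and not a number: the limit of > 25000 nM in this assay, at which 3 of the 3 values shown sit.

The compounds shown leave open whether swapping ethyl, fluoro and trifluoromethyl changes the effect on these cells at all, and at what amount any of the three would act.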